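The source may report more compounds than this note shows. Statements on the series, on what has been measured and on what is new or still open speak of the compounds shown alone.

The measured compounds and their values:

Compound 1, `NCCNc1cc(N2CCN(c3ccccc3)CC2)nc2ccccc12`: in an ADME assay on HEp-2 cells (Homo sapiens) for cytotoxicity, read by CCK-8 assay, with a stated time of 6 days (on this read-out lower numbers stand for higher toxicity in this test and higher numbers for lower toxicity in this test), compound 1 gives 20800 nM.
Compound 2, `NCCNc1cc(N2CCN(C(=O)C3(c4ccccc4)CCC3)CC2)nc2ccccc12`: in this assay compound 2 gives > 100000 nM, which is a limit of the assay and not a number.
Compound 3, `CCC(=O)N1CCN(c2cc(NCCN)c3ccccc3n2)CC1`: in this assay compound 3 gives > 100000 nM, again a limit of the assay.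

Compound 3 therefore stands at the top of the numbers shown, at the limit of > 100000 nM in this assay, at which 2 of the 3 values shown sit, so its position relative to compound 2 cannot be resolved. Against compound 1 the picture is clearer: an at least 4.8-fold higher number from compound 1 to compound 3 (0.68 log units; beyond the scatter). The other step that ends in compound 3 gives no size: a step that the two limits leave unreadable from compound 2 to compound 3.

Compound 4, `CC(C)C(=O)N1CCN(c2cc(NCCN)c3ccccc3n2)CC1`, differs from compound 3 by methyl in place of hydrogen on a saturated chain carbon bound to a carbonyl carbon and a saturated chain carbon. Among the compounds with values here, of the measured steps, only the one from compound 2 to compound 3 touches the same carbonyl substituent, and it is unreadable; the step from compound 1 to compound 3 shows only that the propanoyl compound sits at the limit. On this evidence no step beyond the scatter is expected, and a step that the limit leaves unreadable from compound 3 to compound 4 is the estimated change. Compound 4 is expected to give 150000 nM, in a range from 50000 nM to 400000 nM.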

Compound 4, half-maximal cytotoxic concentration: > 100000 nM
Compound 4 ended at the assay's limit (the forecaster's own chance of this, stated with the estimate: 75%); the middle value does not contradict the limit.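

Methyl in place of hydrogen on a saturated chain carbon bound to a carbonyl carbon and a saturated chain carbon leaves the reading at the limit of this assay, so the limit now holds for isopropylcarbonyl as well as for propanoyl on the amine nitrogen in a ring. Isopropylcarbonyl in place of phenyl on that nitrogen gives an at least 4.8-fold higher number from compound 1 to compound 4 (0.68 log units; beyond the scatter), so a second small carbonyl-linked group stands apart from the phenyl of compound 1. The steps to compound 4 from compound 2 and from compound 3 cannot be read, and compound 4 joins those two compounds at the same limit: the limit of > 100000 nM in this assay, at which 3 of the 4 values shown sit.

Going by these compounds, whether methyl in this place changes the number at all stays open, as the limit hides any difference between compound 3 and compound 4. Also open, on these data alone, is whether a tert-butyl or an aminomethyl group on the carbonyl carbon would give a reading that lies under the limit, as compound 1 does with its phenyl on the ring nitrogen.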